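The source may report more compounds than this note shows. Statements on the series, on what has been measured and on what is new or still open speak of the compounds shown alone.

Compound 1 `CC(C)n1ncc2c(C(=O)NC3CCCC3)cccc21` gives > 40000 nM in a functional assay on MCF7 cells (Homo sapiens) for inhibition, read by MTT assay, with a stated time of 72 h; on this read-out lower numbers stand for stronger inhibition and higher numbers for weaker inhibition; this is a limit, not a number.
Compound 2 `CC(C)n1ncc2c(C(=O)NCc3ccccc3)cccc21` gives > 40000 nM in this assay; this too is a limit.
Compound 3 `CC(C)n1ncc2c(C(=O)NCc3cn(-c4ccc(F)cc4)nn3)cccc21` gives > 40000 nM in this assay; again a limit.

Compound 3 therefore stands at a limit only, and so do the two other compounds, as the limit of > 40000 nM in this assay, at which 3 of the 3 values shown sit, shows. The unmeasured compound 4 `CC(C)n1ncc2c(C(=O)NCc3cn(-c4ccccc4F)nn3)cccc21` differs from compound 3 in one place: 2-fluorophenyl in place of 4-fluorophenyl on an aromatic nitrogen. Among the measured compounds shown here, the only measured step between neighbouring compounds, a step that the two limits leave unreadable from compound 1 to compound 2, cannot be read, since both of its ends sit at a limit, so it offers no size. For the measured compounds named here, no measured step exchanges one fluorophenyl for another, so nothing bears directly on the change from compound 3 to compound 4. Because the limit of > 40000 nM in this assay, at which 3 of the 3 values shown sit, holds every value seen so far, compound 4 is expected to sit at the same limit, and a step that the limit leaves unreadable from compound 3 to compound 4 is expected to be no step beyond the scatter. Compound 4 is thus estimated at 60000 nM in this assay, within 20000 nM to 200000 nM.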

Compound 4, half-maximal inhibitory concentration: > 40000 nM
Compound 4: only a limit was reported; the forecaster's own chance of this, stated with the estimate: 90%; the middle value lies beyond the limit too.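

Compound 3 and compound 4 both give a limit rather than a number, so the step between them cannot be read: the limit of > 40000 nM in this assay, at which 4 of the 4 values shown sit.

The compounds shown leave open how strongly any of them acts in this assay, and whether 2-fluorophenyl and 4-fluorophenyl differ there at all.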